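Swapping pyrazolyl for dimethylamino on a rapidly cleared compound

The source may report more compounds than this note shows. Statements on the series, on what has been measured and on what is new or still open speak of the compounds shown alone.

So far, three compounds have been measured in an ADME assay on microsomes from liver (Rattus norvegicus) for metabolic stability; a lower number here means slower removal, a higher number faster removal of the compound. Compound 1 `CNc1nc(NC(C#N)(C2CC2)C2CC2)nc(-n2cncn2)n1` gives 3.7 mL/min/kg, compound 3 `CCCC(C#N)(CC)Nc1nc(NC)nc(-n2cncn2)n1` gives 29 mL/min/kg, and compound 2 `CNc1nc(NC2(C#N)CCCCC2)nc(-n2cccn2)n1` gives 103 mL/min/kg. Compound 2 therefore has the highest of the three numbers, and its gaps to both of the others lie beyond the usual scatter of repeated measurements.

The next compound to be tested is compound 4 `CNc1nc(NC2(C#N)CCCCC2)nc(N(C)C)n1`. It matches compound 2 except at one place, with dimethylamino in place of 1H-pyrazol-1-yl on an aromatic carbon.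

Within the data shown here, no two measured compounds differ in only one place, so the data give no direct measure of this swap. Compound 1 and compound 3 each differ from compound 2 in more than one place, so their lower numbers cannot be tied to this position alone. The best available guide is compound 2 itself at 103 mL/min/kg, and the expectation stays close to that number. A small fall within the scatter is expected, an estimated 1.3-fold lower number from compound 2 to compound 4 (0.11 log units; within the scatter). Compound 4 is estimated to give 80 mL/min/kg, with an expected range from 35 mL/min/kg to 180 mL/min/kg.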

Compound 4, clearance: 276 mL/min/kg
The estimate for compound 4 lay 3.5-fold (0.54 log units) below the measured number, outside the stated range (above it).
By their numbers in this assay, from the lowest: compound 1; then compound 3; then compound 2; then compound 4.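

Among these compounds, this is the first pair of compounds that differ in only one place, so the group on this aromatic carbon, opposite the ring nitrogen, can now be judged by itself in this assay. Putting dimethylamino in place of 1H-pyrazol-1-yl gives a 2.7-fold higher number from compound 2 to compound 4 (0.43 log units; beyond the scatter) and, although modest, this step shows that the number responds to the group at this position even in a compound that is already removed rapidly. For this pair, replacing the five-membered aromatic ring with a group that has no ring moves the number up, while the data offer no explanation for that rise.

A single pair cannot show whether the rise goes with the loss of the aromatic ring or with dimethylamino in particular, and a methoxy group or a morpholine ring at the same carbon would help to separate those two readings. From the compounds shown here alone, it also remains open whether the same swap would move the number in the same direction on the cores of compound 1 and compound 3, each of which differs from compound 2 in more than one place.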